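Octyl to 3-Chlorophenyl on a Weak Hydroxyanilide

A few compounds are considered here, and "the series" means these few. Any claim that something is new, unique, unknown or untested is made for them only; others in the source may bear on it.

Measured so far:
compound 1, `CCCCCCCCC(=O)N1c2ccccc2CCC1C(=O)Nc1ccccc1C(F)(F)F`: 4320 nM
compound 2, `O=C(Nc1cc(C(F)(F)F)cc(C(F)(F)F)c1)C1CCc2ccccc2N1C(=O)c1ccc(Cl)cc1`: 4230 nM
compound 3, `CCCCCCCCC(=O)N1c2ccccc2CCC1C(=O)Nc1ccccc1O`: 45200 nM

The three compounds share one core and were all tested in a functional assay on PC-3 cells (Homo sapiens) for cytotoxicity, read by sulforhodamine B assay, with a stated time of 72 h; on this read-out higher numbers stand for weaker inhibition of growth and lower numbers for stronger inhibition of growth. Compound 3 stands at the highest number of the three: the step of a 10-fold higher number from compound 1 to compound 3 (1.02 log units; beyond the scatter) is large and beyond the scatter, and compound 2 lies a similar distance below compound 3, so compound 3 gives the weakest inhibition of growth among the measured set.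

Compound 4, `O=C(Nc1ccccc1O)C1CCc2ccccc2N1C(=O)c1cccc(Cl)c1`, keeps the hydroxy-bearing anilide of compound 3 and differs from it in one place: 3-chlorophenyl in place of octyl on a carbonyl carbon. For the measured compounds named here, no measured step traces this change directly. Compound 1 and compound 2 differ from each other in more than one place, and their values in this assay lie within the scatter of each other, so they give no clean reading on swapping the group at the carbonyl carbon. The account therefore expects no step beyond the scatter in this assay for this change, with the direction left open.

For compound 4 the expected value in this assay is 30000 nM, within a range from 8000 nM to 120000 nM, which means an expected step of a 1.5-fold lower number from compound 3 to compound 4 (0.18 log units; within the scatter).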

Compound 4, concentration for 50% growth inhibition: 23300 nM
The estimate for compound 4 lay 1.3-fold (0.11 log units) above the measured number; the measured number falls inside the stated range.
By their numbers in this assay, from the lowest: compounds 2 and 1 (each within the scatter of the next); then compounds 4 and 3 (each within the scatter of the next).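

Swapping octyl for 3-chlorophenyl on the carbonyl carbon gives the first direct reading of this position in this assay, and the result is a 1.9-fold lower number from compound 3 to compound 4 (0.29 log units; within the scatter) on the hydroxy-bearing anilide. An open chain of 8 heavy atoms gives way to a six-membered aromatic ring with a chlorine, 7 heavy atoms in all, and the read-out shows no change that can be told from the scatter, something compound 1 and compound 2 could not show, as they differ in more than one place. No measurement offered here gives a reason for this result.

On these data alone, it remains open whether the same swap would read the same way on the trifluoromethyl anilide of compound 1, where the starting number is lower, or whether the small step belongs to the hydroxy-bearing anilide alone. Also open, as far as these compounds go, is how this carbonyl position would respond to groups of another kind, such as a longer chain, a chain ending in an amine or a phenyl ring carrying a carboxylic acid.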